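A few compounds are considered here, and "the series" means these few. Any claim that something is new, unique, unknown or untested is made for them only; others in the source may bear on it.

Among the compounds with values here, compound 1 `[O-][S+](CCC(F)(Cl)C(F)(F)Cl)c1nc2ccccc2s1` is the only member of this small set with a plain number in a functional assay on HepG2 cells (Homo sapiens) for cytotoxicity, read by MTT assay, with a stated time of 48 h; a higher number here means a weaker inhibitor, a lower number a stronger inhibitor: there compound 1 gives 13500 nM. Compound 2 `FC(F)=C(F)CCSc1nccs1` and compound 3 `FC(F)=C(F)CCSc1ncc(Cl)s1` share a different core, and how that core differs from the core of compound 1 is not broken down here. In this assay compound 2 reaches only a limit of the assay, > 120000 nM. Compound 3 likewise reaches only a limit in this assay, > 120000 nM. The change from compound 2 to compound 3 is chloro in place of hydrogen on an aromatic carbon, and its step, a step that the two limits leave unreadable from compound 2 to compound 3, cannot be read because both values sit at the limit of > 120000 nM in this assay, at which 2 of the 3 values shown sit. Compound 4 `[O-][S+](CCC(F)(Cl)C(F)(F)Cl)c1nc2ccc(Cl)cc2s1`, not yet measured, arises from compound 1 by the same kind of change, (chloro in place of hydrogen on an aromatic carbon); here the place is a six-membered aromatic ring of carbon only, part of a fused system, meta and para to a fused ring, rather than a five-membered ring with one nitrogen and one sulfur. With the earlier step unreadable, the step expected here, a 1.4-fold lower number from compound 1 to compound 4 (0.13 log units; within the scatter), rests on the value of compound 1, 13500 nM, and is expected to stay within the usual scatter. Compound 4 is therefore estimated at 10000 nM, between 4000 nM and 30000 nM.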

Compound 4, half-maximal inhibitory concentration: 6900 nM
Compound 4: middle estimate off by 1.4-fold (0.16 log units), on the high side, and the stated range covers the measured number.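

In this assay, chloro in place of hydrogen on a six-membered aromatic ring of carbon only gives a 2.0-fold lower number from compound 1 to compound 4 (0.29 log units; within the scatter) and so, in this single pair, the difference stays inside the usual scatter of repeated measurements. The same kind of change on the other core, from compound 2 to compound 3, cannot be read, because both values there are limits of the assay and not numbers: the limit of > 120000 nM in this assay, at which 2 of the 4 values shown sit. The series therefore shows neither that the change carries from one core to the other nor that it fails to, and the two steps cannot be compared.

Still open, from the compounds shown here alone, is whether a group other than chloro on this aromatic carbon, such as an amine or a carboxylic acid, would shift the number beyond the scatter. Also open, going by these compounds, is whether a longer chain in place of the halogenated side chain would bring the other core to a plain number, which would give a step that can be read there.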